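This account rests on a few compounds, and the source may have more. Where it says the series, first, only, none or still open, it means among the compounds named here.

Working notes on the series. Of the compounds shown here, three of a shared core have been measured so far: compound 1 `Cc1ccc(Nc2nc(C)c(C(=O)/C=C/c3ccc(Cl)cc3)s2)cc1`, compound 2 `Cc1nc(Nc2cccc(Cl)c2)sc1C(=O)/C=C/c1ccc(Cl)cc1` and compound 3 `Cc1ccc(Nc2nc(C)c(C(=O)/C=C/c3ccccc3)s2)cc1`, all in a functional assay on Bel-7402 cells (Homo sapiens) for cytotoxicity, read by MTT assay; a higher number here means a weaker inhibitor, a lower number a stronger inhibitor. For compound 1 the read-out is a limit of the assay, > 25000 nM. For compound 2 the read-out is likewise a limit, > 25000 nM. For compound 3 the read-out is again a limit, > 25000 nM. Compound 3 therefore stands at the edge of what the assay reports, together with every other value shown, all of which sit at the limit of > 25000 nM in this assay, at which 3 of the 3 values shown sit. The two steps between measured compounds, a step that the two limits leave unreadable from compound 1 to compound 2 and a step that the two limits leave unreadable from compound 1 to compound 3, are unreadable in size, both ends being limits.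

Compound 4 `Cc1nc(Nc2ccccc2)sc1C(=O)/C=C/c1ccccc1` differs from compound 3 by hydrogen in place of methyl on an aromatic carbon, which read one bond further out is 4-methylphenyl to phenyl. Within the data shown here, no measured step touches this change: the step from compound 1 to compound 3 alters the chloro on the other aryl ring, and the step from compound 1 to compound 2 exchanges the whole 4-methylphenyl for 3-chlorophenyl. No readable size exists on which to ground a step in this assay in either direction, so none beyond the scatter is expected. Compound 4 is estimated to give 35000 nM, with a range of 12000 nM to 120000 nM, most likely reported as a limit once more. The expected step is a step that the limit leaves unreadable from compound 3 to compound 4, nothing beyond the scatter.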

Compound 4, half-maximal inhibitory concentration: > 25000 nM
Compound 4: no number, only a limit; the forecaster's own chance of this, stated with the estimate: 85%; the middle value does not contradict the limit.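

No new step can be read from compound 3 to compound 4 in this assay, as both read-outs are limits, and the series as a whole sits at one edge of the assay: the limit of > 25000 nM in this assay, at which 4 of the 4 values shown sit.

The compounds shown leave open whether any change on the shared core moves the read-out in this assay, and by how much.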